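From Chloro to Nitro in a Level Series

The source may hold more compounds than are shown below. What is called first, only, known or untested is meant among the compounds shown, and "the series" means these compounds.

In a functional assay, read by spectrophotometry, with a stated time of 30 min (a lower number here means a stronger inhibitor, a higher number a weaker inhibitor), compound 1 `CC(C)(C)c1cc(/C=C/C(=O)NCCC2CCN(Cc3ccccc3F)CC2)cc(C(C)(C)C)c1O` gives 55900 nM, compound 2 `CC(C)(C)c1cc(/C=C/C(=O)NCCC2CCN(Cc3ccc(F)cc3F)CC2)cc(C(C)(C)C)c1O` gives 62400 nM, and compound 3 `CC(C)(C)c1cc(/C=C/C(=O)NCCC2CCN(Cc3cccc(Cl)c3)CC2)cc(C(C)(C)C)c1O` gives 83100 nM. Compound 3 therefore stands level with the other two, all within the scatter of one another. Compound 4 `CC(C)(C)c1cc(/C=C/C(=O)NCCC2CCN(Cc3cccc([N+](=O)[O-])c3)CC2)cc(C(C)(C)C)c1O` has nitro in place of chloro on an aromatic carbon, meta to a large group: nitro in place of chloro on an aromatic carbon. Among the measured compounds shown here, no measured pair makes this exact swap. The closest guides are a 1.1-fold higher number from compound 1 to compound 2 (0.05 log units; within the scatter), a 1.5-fold higher number from compound 1 to compound 3 (0.17 log units; within the scatter) and a 1.3-fold higher number from compound 2 to compound 3 (0.12 log units; within the scatter), and all three stay within the scatter. On that evidence, no step beyond the scatter is expected in this assay. The expected result is a 1.2-fold lower number from compound 3 to compound 4 (0.07 log units; within the scatter). Compound 4 is estimated at 70000 nM, with a range from 30000 nM to 150000 nM.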

Compound 4, half-maximal inhibitory concentration: 78100 nM
Estimate against measurement, compound 4: 1.1-fold (0.05 log units) below; measured number inside the range.
By their numbers in this assay, from the lowest: compounds 1, 2, 4 and 3 (each within the scatter of the next).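

Nitro brings three heavy atoms and two hydrogen-bond acceptors where chloro brought one heavy atom and no acceptors, yet in (this assay) this larger change on an aromatic carbon, meta to a large group, leaves the result within the scatter (a 1.1-fold lower number from compound 3 to compound 4 (0.03 log units; within the scatter)). Compound 4 also stays level with the fluorinated compounds (a 1.3-fold higher number from compound 2 to compound 4 (0.10 log units; within the scatter); a 1.4-fold higher number from compound 1 to compound 4 (0.15 log units; within the scatter)). Nothing here explains this flatness. As far as these compounds go, an amine or a carboxylic acid at this position remains open, and either could show whether this position can ever move the number beyond the scatter.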